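A methoxymethyl chain from compound 3 to compound 4

The source may report more compounds than this note shows. Statements on the series, on what has been measured and on what is new or still open speak of the compounds shown alone.

Results in a functional assay on HL-60 cells (Homo sapiens) for cytotoxicity, read by WST assay, with a stated time of 48 h (on this read-out lower numbers stand for stronger inhibition and higher numbers for weaker inhibition), so far:
Compound 1 `COC[C@H](C(C)C)C(c1ccc(O)c(OC)c1)c1ccc(O)c(OC)c1` gives 72000 nM as a number
Compound 2 `COc1cc(C(c2ccc(O)c(OC)c2)[C@@H](CO)C(C)C)ccc1O` gives > 100000 nM as a limit
Compound 3 `COc1cc(C(c2ccc(O)c(OC)c2)[C@@H](C)[C@H](C)CO)ccc1O` gives > 100000 nM as a limit

Compound 3 stands at > 100000 nM here, which is a limit and not a number. Compound 4 `COC[C@@H](C)[C@@H](C)C(c1ccc(O)c(OC)c1)c1ccc(O)c(OC)c1` carries 2-(methoxymethyl)-1-methylpropyl in place of 2-(hydroxymethyl)-1-methylpropyl on a saturated chain carbon bound to two aromatic carbons. The closest measured change runs the other way (an at least 1.3-fold higher number from compound 1 to compound 2 (0.14 log units; that floor lies within the scatter)), and the second step from compound 1 agrees (an at least 1.3-fold higher number from compound 1 to compound 3 (0.14 log units; that floor lies within the scatter)). The third step (a step that the two limits leave unreadable from compound 2 to compound 3) gives no size. Compound 1 gives 72000 nM as a true number, so compound 4 is expected to land near it. In this assay the expected step is small (an at least 1.4-fold lower number from compound 3 to compound 4 (0.15 log units; that floor lies within the scatter)). Compound 4 is estimated at 70000 nM (range 32000 nM to 150000 nM).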

Compound 4, half-maximal inhibitory concentration: 85000 nM
Compound 4: the middle estimate sits 1.2-fold (0.08 log units) below what was measured; the measured number falls inside the stated range.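

In this assay, 2-(methoxymethyl)-1-methylpropyl in place of 2-(hydroxymethyl)-1-methylpropyl yields a true number where there was only a limit, with an at least 1.1-fold lower number from compound 3 to compound 4 (0.07 log units; that floor lies within the scatter) and an at least 1.1-fold lower number from compound 2 to compound 4 (0.07 log units; that floor lies within the scatter), both floors within the scatter. The two methoxymethyl chains cannot be told apart, with a 1.2-fold higher number from compound 1 to compound 4 (0.07 log units; within the scatter), also within the scatter. How far the hydroxymethyl chains lie from compound 4 stays unread, as their values are limits: the limit of > 100000 nM in this assay, at which 2 of the 4 values shown sit.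

The compounds shown leave open whether an amine, a carboxylic acid or a longer chain in place of the methoxymethyl group would move the number at this position.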